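Notes on the lactam change from compound 3 to compound 4

A few compounds are considered here, and "the series" means these few. Any claim that something is new, unique, unknown or untested is made for them only; others in the source may bear on it.

In a toxicity assay on HepG2 2.2.15 cells (Homo sapiens) for cytotoxicity, read by CellTiter-Glo (a higher number here means that more compound is tolerated, a lower number that less compound is tolerated), compound 3 `CC1(C)CC(=O)N(c2cnn3c2CN(C(=O)Nc2cc(F)c(F)c(F)c2)C(C2CC2)C3)C1` gives 115000 nM and sits within the scatter of compound 2 `O=C1CC(Oc2ncc(F)cn2)CN1c1cnn2c1CN(C(=O)Nc1cc(F)c(F)c(F)c1)C(C1CC1)C2` at 96200 nM while compound 1 `O=C1OC(c2ccccc2)CN1c1cnn2c1CN(C(=O)Nc1cc(F)c(F)c(F)c1)C(C1CC1)C2` lies well apart from both at 7410 nM on the same scale. Compound 4 `O=C1CC(C(F)(F)F)CN1c1cnn2c1CN(C(=O)Nc1cc(F)c(F)c(F)c1)C(C1CC1)C2` has 2-oxo-4-(trifluoromethyl)pyrrolidin-1-yl in place of 4,4-dimethyl-2-oxopyrrolidin-1-yl on an aromatic carbon and the core is unchanged. For the measured compounds named here, the one measured step at this place, a 16-fold higher number from compound 1 to compound 3 (1.19 log units; beyond the scatter), is large, but it removes the 2-oxo-5-phenyl-1,3-oxazolidin-3-yl group, which compound 4 also lacks. No step beyond the scatter is therefore expected in this assay and the expected step, leaning slightly lower, is a 1.4-fold lower number from compound 3 to compound 4 (0.16 log units; within the scatter) as a working figure. For compound 4 the estimate is 80000 nM with an expected range from 30000 nM to 160000 nM for now.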

Compound 4, half-maximal cytotoxic concentration: 115000 nM
Compound 4: the middle estimate sits 1.4-fold (0.16 log units) below what was measured; measured number inside the range.
By their numbers in this assay, from the lowest: compound 1; then compounds 2, 3 and 4 (each within the scatter of the next).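

In this assay, 2-oxo-4-(trifluoromethyl)pyrrolidin-1-yl for 4,4-dimethyl-2-oxopyrrolidin-1-yl gives no change at the digits printed from compound 3 to compound 4 (within the scatter), and trifluoromethyl for (5-fluoropyrimidin-2-yl)oxy on a saturated ring carbon gives a 1.2-fold higher number from compound 2 to compound 4 (0.08 log units; within the scatter), so three differently substituted lactams now read alike. Leaving 2-oxo-5-phenyl-1,3-oxazolidin-3-yl for the new lactam gives a 16-fold higher number from compound 1 to compound 4 (1.19 log units; beyond the scatter), so among these four the low number goes only with that group. Nothing measured here accounts for these steps.

Still open, on these data alone, is whether a primary amine or a carboxylic acid on the lactam would stay level with these numbers. Also open, as far as these compounds go, is whether a phenyl on the lactam would bring the low number back.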